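Dimethylamino for Imidazolyl on a Propargylic Carbon

A few compounds are considered here, and "the series" means these few. Any claim that something is new, unique, unknown or untested is made for them only; others in the source may bear on it.

Measured compounds:
compound 1, `CC(C#CCn1ccnc1)N1CCCC1=O`: > 100 mg/kg
compound 2, `CC(C#CCN(C)C)N1CCCC1=O`: 6.6 mg/kg
compound 3, `COC(=O)N(C)CC#CCn1ccnc1`: 4.5 mg/kg

In a functional assay on the whole organism for agonist activity, with Mus musculus as the target (on this read-out lower numbers stand for an effect already at smaller amounts and higher numbers for an effect only at larger amounts of compound), compound 1 gives > 100 mg/kg, and this is a limit of the assay, not a number. The change dimethylamino in place of 1H-imidazol-1-yl on a saturated chain carbon bound to a triple-bonded carbon brought an at least 15-fold lower number from compound 1 to compound 2 (1.18 log units; beyond the scatter), a step whose true size is open because compound 1 sits at the limit of > 100 mg/kg in this assay, at which 1 of the 3 values shown sits. Compound 3 gives 4.5 mg/kg, within the scatter of compound 2. The difference between the core of compound 3 and the core of compound 1 is not broken down here. Compound 4, `COC(=O)N(C)CC#CCN(C)C`, carries the same change, (dimethylamino in place of 1H-imidazol-1-yl on a saturated chain carbon bound to a triple-bonded carbon). A lower number is expected for compound 4, with a 1.8-fold lower number from compound 3 to compound 4 (0.26 log units; within the scatter), resting on the step from compound 1 to compound 2 in this assay but taken as smaller, since that step was measured from a limit. Compound 4 is thus estimated at 2.5 mg/kg, between 0.8 mg/kg and 8 mg/kg.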

Compound 4, dose for half-maximal effect: 9.7 mg/kg
Estimate against measurement, compound 4: 3.9-fold (0.59 log units) below; measured number outside the range, above it.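

In this assay the same change brought a 2.2-fold higher number from compound 3 to compound 4 (0.33 log units; beyond the scatter), so it did not repeat on this core what it did on the core of compound 1. Carried from one core to the other, the change kept neither its size nor its direction: the same change on two cores in this assay, an at least 15-fold lower number (1.18 log units; beyond the scatter) from compound 1 to compound 2 and a 2.2-fold higher number (0.33 log units; beyond the scatter) from compound 3 to compound 4, at least 32-fold (1.51 log units) apart, beyond the scatter of two such steps. As far as these compounds go, compound 1 gives > 100 mg/kg, which is a limit and not a number, and the size of the earlier step therefore stays unknown, while two cores cannot show what sets the difference: the limit of > 100 mg/kg in this assay, at which 1 of the 4 values shown sits.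

The compounds shown leave open how another amine such as diethylamino, or another ring such as pyrazolyl, would behave at this place on either core. Also open, from the compounds shown here alone, is what a longer chain carrying the dimethylamino would do.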